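Halogen swap on the benzylidene arm of compound 3

The source may report more compounds than this note shows. Statements on the series, on what has been measured and on what is new or still open speak of the compounds shown alone.

Measured compounds:
- compound 1, `C=CCn1c(=O)/c(=C\c2cccc(Cl)c2)[nH]c(=O)/c1=C\c1ccccc1OC`, 4600 nM in a functional assay on BGC-823 cells (Homo sapiens) for cytotoxicity, read by CCK-8 assay, with a stated time of 72 h; a higher number here means a weaker inhibitor, a lower number a stronger inhibitor
- compound 2, `COc1ccccc1/C=c1/[nH]c(=O)/c(=C\c2cccc(Cl)c2Cl)[nH]c1=O`, in this assay compound 2 is reported as "not active" (no number reported)
- compound 3, `C=CCn1c(=O)/c(=C\c2ccccc2Cl)[nH]c(=O)/c1=C\c1ccccc1OC`, in this assay compound 3 gives 4600 nM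

Compound 3 stands level with compound 1 on the numbers shown: the step of no change at the digits printed from compound 1 to compound 3 (within the scatter) lies within the scatter, and compound 2 offers no number to place beside it. Compound 4, `C=CCn1c(=O)/c(=C\c2cc(Br)ccc2F)[nH]c(=O)/c1=C\c1ccccc1OC`, differs from compound 3 in one place: 5-bromo-2-fluorophenyl in place of 2-chlorophenyl on a double-bonded chain carbon bound to an aromatic carbon. Among the measured compounds shown here, no measured step varies the halogen pattern on this ring in that way; the only step that touches this ring, no change at the digits printed from compound 1 to compound 3 (within the scatter), moved the chlorine between two positions without a change beyond the scatter. Compound 2 carries two chlorines on that ring and lacks the allyl group, so it differs from compound 3 in two places and cannot be read as a single step. On this basis the step of a 1.2-fold higher number from compound 3 to compound 4 (0.08 log units; within the scatter) is expected to be small, within the scatter. For compound 4 the estimate in this assay is 5500 nM, with a range from 2000 nM to 20000 nM.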

Compound 4, half-maximal inhibitory concentration: "not active" (no number reported)
For compound 4 the study gives words and no number, so the estimate cannot be set against anything.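

Compound 4 is reported in this assay only in words, as "not active", so no new step can be read between compound 3 and compound 4. No measured evidence bears on this result. The compounds shown leave open how the 5-bromo-2-fluorophenyl group itself relates to that outcome.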